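This account rests on a few compounds, and the source may have more. Where it says the series, first, only, none or still open, it means among the compounds named here.

The measured compounds:

Compound 1, `Cc1ccc(C(=O)CSc2nnc(C)n2N2C(=O)c3ccccc3C2=O)cc1`, in a functional assay on A549 cells (Homo sapiens) for cytotoxicity, read by MTT assay, with a stated time of 48 h (a lower number here means a stronger inhibitor, a higher number a weaker inhibitor), gives > 200000 nM, a limit of the assay rather than a number.
Compound 2, `C#CCSc1nnc(C)n1N1C(=O)c2ccccc2C1=O`, in this assay gives > 200000 nM, again a limit of the assay.
Compound 3, `CCCc1nnc(SCC(=O)c2ccc(C)cc2)n1N1C(=O)c2ccccc2C1=O`, in this assay gives > 200000 nM, again a limit of the assay.

All three share a core built on a triazole-like ring carrying a phthalimide-type group, and differ only in two side groups. Compound 3 differs from compound 1 by ethyl in place of hydrogen on a saturated chain carbon bound to an aromatic carbon. The step from compound 1 to compound 3 in this assay is a step that the two limits leave unreadable from compound 1 to compound 3, because both compounds sit at the limit of > 200000 nM in this assay, at which 3 of the 3 values shown sit.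

Compound 4, `C#CCSc1nnc(CCC)n1N1C(=O)c2ccccc2C1=O`, has not yet been measured in this assay. It is reached from compound 3 by ethynyl in place of (4-methylphenyl)carbonyl on a saturated chain carbon bound to a sulfur. The same change, word for word at the same place, is made between two measured compounds: compound 2 differs from compound 1 by ethynyl in place of (4-methylphenyl)carbonyl on a saturated chain carbon bound to a sulfur. In this assay that step is a step that the two limits leave unreadable from compound 1 to compound 2, because both compounds sit at the limit of > 200000 nM in this assay, at which 3 of the 3 values shown sit.

With nothing to read from the measured step, the expectation for compound 4 rests on the fact that compound 1, compound 2 and compound 3 all sit at the limit of > 200000 nM in this assay, at which 3 of the 3 values shown sit. The step from compound 3 to compound 4 is therefore expected to be a step that the limit leaves unreadable from compound 3 to compound 4. Compound 4 is estimated at 400000 nM, most likely between 150000 nM and 2000000 nM, and the assay is expected to report only a limit again.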

Compound 4, half-maximal inhibitory concentration: > 200000 nM
Compound 4 gave a limit, no number; the forecaster's own chance of this, stated with the estimate: 85%; the middle value is on the limit's open side.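

In this assay compound 4 gives > 200000 nM, a limit of the assay and not a number. No step from compound 2 or compound 3 to compound 4 can therefore be read, as all the compounds share one limit: the limit of > 200000 nM in this assay, at which 4 of the 4 values shown sit.

The compounds shown leave open how strong any of them is and what either side-group change does to that strength in this assay.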